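The source may hold more compounds than are shown below. What is called first, only, known or untested is meant among the compounds shown, and "the series" means these compounds.

Measured compounds and their values in an assay on CHO cells for displacement of a labelled ligand from adenosine receptor A1 (Homo sapiens), read by scintillation counting, with a stated time of 90 min; a lower number here means a stronger inhibitor, a higher number a weaker inhibitor:

Compound 1, `N#Cc1c(N)nc(SCc2cccc(C(N)=O)c2)c(C#N)c1-c1ccc(OCC2CC2)cc1`: 83 nM
Compound 2, `CCOc1ccc(-c2c(C#N)c(N)nc(SCc3ncc[nH]3)c2C#N)cc1`: 8.2 nM
Compound 3, `N#Cc1c(N)nc(SCc2cccnc2)c(C#N)c1-c1ccc(OCC2CC2)cc1`: 67 nM

Compound 3 stands second highest of the three numbers. Its nearest neighbour is compound 1, and the step from that compound reads a 1.2-fold lower number from compound 1 to compound 3 (0.09 log units; within the scatter), so the two cannot be told apart. Compound 2 is the furthest from it, with a much lower number, and the two differ in more than one place, so only their two values can be compared.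

Compound 4, `N#Cc1c(N)nc(SCc2ncc[nH]2)c(C#N)c1-c1ccc(OCC2CC2)cc1`, has not yet been measured. It differs from compound 3 in one place: 1H-imidazol-2-yl in place of pyridin-3-yl on a saturated chain carbon bound to a sulfur. Among the measured compounds shown here, the only measured step, the one from compound 1 to compound 3, exchanges a different ring on a saturated chain carbon bound to a sulfur and lies within the scatter, so it gives no direct guide. Compound 2, however, carries the same 1H-imidazol-2-yl group that enters here and gives 8.2 nM, well below compound 3 at 67 nM. A lower number for compound 4 in this assay is therefore expected, with a step of about a 5.6-fold lower number from compound 3 to compound 4 (0.75 log units; beyond the scatter). The estimate for compound 4 is 12 nM, within a range from 4 nM to 40 nM.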

Compound 4, inhibition constant: 235 nM
The estimate for compound 4 lay 20-fold (1.29 log units) below the measured number; measured number above the stated range.
By their numbers in this assay, from the lowest: compound 2; then compounds 3 and 1 (each within the scatter of the next); then compound 4.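

In this assay the result for the 1H-imidazol-2-yl group is read twice on a saturated chain carbon bound to a sulfur: a 3.5-fold higher number from compound 3 to compound 4 (0.54 log units; beyond the scatter) and a 2.8-fold higher number from compound 1 to compound 4 (0.45 log units; beyond the scatter) both end on a weaker inhibitor, so with the cyclopropyl group in place this ring does worse here than pyridin-3-yl or 3-carbamoylphenyl. The step of a 29-fold higher number from compound 2 to compound 4 (1.46 log units; beyond the scatter) changes only cyclopropyl in place of methyl on a saturated chain carbon bound to an oxygen on an aromatic ring, and it shows that the low number of compound 2 belongs to the pairing of the 1H-imidazol-2-yl group with that methyl and does not travel with the ring alone. Nothing measured here explains why the steps run this way.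

Whether cyclopropyl in place of methyl moves the number as far with pyridin-3-yl on the sulfur chain stays open, as the compounds shown hold that change only with the 1H-imidazol-2-yl group. Also open, as far as these compounds go, is what a 1-methylimidazol-2-yl group, with a methyl on the ring nitrogen in place of its hydrogen, or a simple amine or carboxylic acid in place of the ring would do.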